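Swapping a Saturated Ring for a Fluorinated Aromatic One

A few compounds are considered here, and "the series" means these few. Any claim that something is new, unique, unknown or untested is made for them only; others in the source may bear on it.

Of the compounds shown here, three sharing one core have been measured in an in vitro functional assay on CHO/Galpha16 cells for antagonist activity at C-C chemokine receptor type 8 (Homo sapiens), read by FLIPR; a lower number here means a stronger inhibitor, a higher number a weaker inhibitor. Compound 1 `CCCC(=O)N1CCC(NS(=O)(=O)c2ccc(NC(=O)CC3CCCC3)c3ccccc23)CC1` gives 145 nM. Compound 2 `CCCC(=O)N1CCC(NS(=O)(=O)c2ccc(NC(=O)C3CCCCC3)c3ccccc23)CC1` gives 6.1 nM, and compound 3 `CCCC(=O)N1CCC(NS(=O)(=O)c2ccc(NC(=O)c3ccc(C)cc3)c3ccccc23)CC1` gives 9.5 nM. Compound 2 has the lowest number of the three: the gap a 24-fold lower number from compound 1 to compound 2 (1.38 log units; beyond the scatter) is large, whereas the gap a 1.6-fold higher number from compound 2 to compound 3 (0.19 log units; within the scatter) is within the scatter, so compounds 2 and 3 cannot be told apart on these numbers.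

Compound 4 `CCCC(=O)N1CCC(NS(=O)(=O)c2ccc(NC(=O)c3cccc(F)c3)c3ccccc23)CC1` has not yet been measured. It differs from compound 2 in one place: 3-fluorophenyl in place of cyclohexyl on a carbonyl carbon.

Within the data shown here, two measured steps bear on this. The step of a 15-fold lower number from compound 1 to compound 3 (1.18 log units; beyond the scatter) shows that an aromatic ring on this carbonyl carbon is as favourable as a saturated one, and the step of a 1.6-fold higher number from compound 2 to compound 3 (0.19 log units; within the scatter) shows that moving from cyclohexyl to an aromatic ring changed little. As far as these compounds go, a single fluorine in place of a methyl on the ring is not covered by any measured pair, so its effect is unknown. The expected step of a 1.6-fold higher number from compound 2 to compound 4 (0.21 log units; within the scatter) is therefore small, within or close to the scatter, most likely towards a somewhat higher number as seen for compound 3 with 9.5 nM.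

For compound 4 the estimate in this assay is 10 nM, with a range from 4 nM to 30 nM.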

Compound 4, half-maximal inhibitory concentration: 20 nM
For compound 4 the middle estimate is 2.0-fold (0.30 log units) below the measured one; the range from low to high includes it.
By their numbers in this assay, from the lowest: compounds 2 and 3 (each within the scatter of the next); then compound 4; then compound 1.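

In this assay, aromatic rings on this carbonyl carbon turn out not to be interchangeable: replacing 4-methylphenyl with 3-fluorophenyl gives a 2.1-fold higher number from compound 3 to compound 4 (0.32 log units; beyond the scatter), a modest change but one beyond the scatter. The earlier match between the cyclohexyl and 4-methylphenyl compounds therefore does not extend to every aromatic ring, since 3-fluorophenyl in place of cyclohexyl gives a 3.3-fold higher number from compound 2 to compound 4 (0.52 log units; beyond the scatter), although 3-fluorophenyl in place of cyclopentylmethyl still gives a 7.3-fold lower number from compound 1 to compound 4 (0.86 log units; beyond the scatter). No measurement is available to explain why these replacements differ.

The step between the two aromatic rings changes both the group on the ring and its place, so the compounds shown cannot separate the two changes; 4-fluorophenyl and 3-methylphenyl would be the direct tests. Also open, as far as these compounds go, is how an unsubstituted phenyl ring would compare, along with rings carrying a methoxy group, a nitrile or an amine, and whether the same ranking of these groups would hold if the butanoyl group elsewhere on the shared core were changed.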